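Fluoro Added to Compound 3: Expected Maximal Response of Compound 4

The source may hold more compounds than are shown below. What is called first, only, known or untested is meant among the compounds shown, and "the series" means these compounds.

Measured so far:
compound 1 `COc1c(F)cccc1C1CCN(c2ccn3c(CC(F)(F)F)nnc3c2C#N)CC1` gives 306%
compound 2 `COc1ccc(F)cc1C1CCN(c2ccn3c(CC(F)(F)F)nnc3c2Cl)CC1` gives 340%
compound 3 `COc1cccc(F)c1C1CCN(c2ccn3c(CC4CC4)nnc3c2Cl)CC1` gives 304%

These values come from a functional assay on CHO cells for agonist activity at metabotropic glutamate receptor 2 (Homo sapiens), read by scintillation counting and GTPgammaS binding, with a stated time of 30 min; on this read-out higher numbers stand for larger maximal responses and lower numbers for smaller maximal responses. Compound 3 has the lowest of the three numbers, though compound 1 sits within the usual scatter of it, while compound 2 lies beyond the scatter above it. Compound 4 `COc1cc(F)cc(F)c1C1CCN(c2ccn3c(CC4CC4)nnc3c2Cl)CC1` differs from compound 3 in one place: fluoro in place of hydrogen on an aromatic carbon. Among the compounds with values here, no measured pair shows this same change, so nothing is known about its effect here. A step of a number 4 percentage points lower from compound 3 to compound 4 (within the scatter) is expected, that is, none clearly beyond the scatter. For compound 4 the estimated maximal response is 300%, in a range from 250% to 350%.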

Compound 4, largest response reached (Emax), in percent of the reference or control that the assay uses: 256%
The estimate for compound 4 lay 44 percentage points above the measured number, and the stated range covers the measured number.
By their numbers in this assay, from the lowest: compound 4; then compounds 3 and 1 (each within the scatter of the next); then compound 2.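

In this assay, swapping hydrogen for fluoro on this aromatic carbon, which turns 2-fluoro-6-methoxyphenyl into 2,4-difluoro-6-methoxyphenyl, gives a number 48 percentage points lower from compound 3 to compound 4 (beyond the scatter), so this change is not neutral here. Within the data shown here, a single added atom para to a large group is enough to shift the maximal response, which the earlier compounds could not show. Nothing available here accounts for the drop.

On these data alone, whether a methyl group or an amine on this same carbon would also lower the response remains open. So does whether fluoro here acts the same way on the nitrile-bearing core of compound 1.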